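The compounds below may be only part of what the source reports. "The series", "measured", "known", "first", "only" and "open" are said of these compounds alone.

Measured so far in a physicochemical assay for solubility, read by nephelometry, measured as kinetic solubility, at pH 6.5, tested at 10 mg/mL (on this read-out higher numbers stand for higher solubility and lower numbers for lower solubility), are two compounds:
- compound 1 `COc1ccc(NC(=O)c2ccccc2C)nc1` gives 12.5 ug/mL here
- compound 2 `Cc1ccccc1C(=O)Nc1ccc(C#N)cn1` gives 6.3 ug/mL here

The series has only these two numbers, and compound 2 at 6.3 ug/mL stands within the scatter of compound 1 at 12.5 ug/mL on this read-out.

Within the data shown here, the change now in view is fluoro in place of cyano on an aromatic carbon and it leads to compound 3 `Cc1ccccc1C(=O)Nc1ccc(F)cn1` which has no measurement yet. Among the measured compounds shown here, the one measured step that bears on it is a 2.0-fold lower number from compound 1 to compound 2 (0.30 log units; within the scatter) for cyano in place of methoxy on the same aromatic carbon, and that step lies within the scatter. Fluoro has no measured example in this set, so the evidence is thin. In this assay no step beyond the scatter is expected, and the direction remains weakly defined. The expected size is a 1.6-fold higher number from compound 2 to compound 3 (0.20 log units; within the scatter) as an estimate that stays within the scatter. Compound 3 is estimated at 10 ug/mL with an expected range from 4 ug/mL to 25 ug/mL as the upper end.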

Compound 3, solubility: 25 ug/mL
Estimate against measurement, compound 3: 2.5-fold (0.40 log units) below; the measured number falls inside the stated range.
By their numbers in this assay, from the lowest: compounds 2, 1 and 3 (each within the scatter of the next, the first and the last beyond it).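

In this assay, the aromatic carbon para to a large group now shows a step beyond the scatter: fluoro in place of cyano gives a 4.0-fold higher number from compound 2 to compound 3 (0.60 log units; beyond the scatter), while the earlier cyano and methoxy pair stayed within the scatter. Fluoro in place of methoxy on the same carbon gives a 2.0-fold higher number from compound 1 to compound 3 (0.30 log units; within the scatter), which is within the scatter, so on this read-out fluoro and methoxy are not separated, and among the three groups only the pair of cyano and fluoro stands apart. Nothing in hand speaks to why the exchange of cyano for fluoro gives a step of this size.

The compounds shown leave open how other groups on this carbon, such as an amine, a carboxylic acid or a chloro group, would read in this assay, and whether any of them would stand clear of both fluoro and methoxy. They also leave open whether fluoro in place of cyano gives a step of similar size on another aromatic carbon of the shared core or on a different core.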